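The source may report more compounds than this note shows. Statements on the series, on what has been measured and on what is new or still open speak of the compounds shown alone.

Working notes on the series. Compound 1 `CCC(CC)=NNc1nc(-c2cccc([N+](=O)[O-])c2)cs1` gives 1130000 nM in a functional assay, with a stated time of 30 min; a higher number here means a weaker inhibitor, a lower number a stronger inhibitor. Compound 2 `CCCC/C(C)=N\Nc1nc(-c2cccc([N+](=O)[O-])c2)cs1` gives 1180000 nM in this assay, and compound 3 `CCCC/C(CC)=N\Nc1nc(-c2cccc([N+](=O)[O-])c2)cs1` gives 1260000 nM. The steps of a 1.0-fold higher number from compound 1 to compound 2 (0.02 log units; within the scatter), a 1.1-fold higher number from compound 1 to compound 3 (0.05 log units; within the scatter) and a 1.1-fold higher number from compound 2 to compound 3 (0.03 log units; within the scatter) all remain within the scatter, so no ordering among these three is claimed. Compound 4 `CCCCCC/C(C)=N\Nc1nc(-c2cccc([N+](=O)[O-])c2)cs1` is not yet measured; it differs from compound 2 by ethyl in place of hydrogen on a saturated chain carbon, four bonds along the chain from a carbon with a double bond to nitrogen. The same kind of change has been measured once, as ethyl in place of hydrogen on a saturated chain carbon, two bonds along the chain from a carbon with a double bond to nitrogen, and it gave a 1.1-fold higher number from compound 1 to compound 3 (0.05 log units; within the scatter). The two cores differ as a group of 7 heavy atoms (6 carbon, 1 nitrogen; no ring) in place of a group of 6 heavy atoms (5 carbon, 1 nitrogen; no ring), on a nitrogen on an aromatic ring. The place is not identical: in the measured pair the ethyl enters two bonds along the chain from a carbon with a double bond to nitrogen, here four bonds along the chain. The expected step from compound 2 to compound 4 is a 1.1-fold higher number from compound 2 to compound 4 (0.04 log units; within the scatter), beside a 1.1-fold higher number from compound 1 to compound 3 (0.05 log units; within the scatter), resting on that single measured step. Compound 4 is expected to give 1300000 nM in this assay.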

Compound 4, half-maximal inhibitory concentration: 1150000 nM
Compound 4: middle estimate off by 1.1-fold (0.05 log units), on the high side, and the stated range covers the measured number.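

In this assay, ethyl in place of hydrogen on a saturated chain carbon, four bonds along the chain from a carbon with a double bond to nitrogen, gives a 1.0-fold lower number from compound 2 to compound 4 (0.01 log units; within the scatter). Set beside the same change two bonds along the chain, the two steps do not differ: the same change on two cores in this assay, a 1.1-fold higher number (0.05 log units; within the scatter) from compound 1 to compound 3 and a 1.0-fold lower number (0.01 log units; within the scatter) from compound 2 to compound 4, 1.1-fold (0.06 log units) apart, within the scatter of two such steps. For the compounds shown here, on these two cores the change therefore carries over as a step within the scatter at both places, but with only two pairs, and neither step beyond the scatter, this does not show that a step of real size would carry over.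

As far as these compounds go, whether any other group moves the number beyond the scatter stays open. That applies to an amine, a carboxylic acid or a ring in place of these chains.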